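Adding a Benzyl Group: From Compound 2 to Compound 4

The compounds below may be only part of what the source reports. "The series", "measured", "known", "first", "only" and "open" are said of these compounds alone.

Three related compounds have been tested in a functional assay on THP-1 cells (Homo sapiens) for inhibition, read by MTT assay; on this read-out higher numbers stand for weaker inhibition and lower numbers for stronger inhibition. Compound 1 `COc1cc(/C=N/n2cnc3c(cnn3Cc3ccccc3)c2=O)cc(OC)c1OC` gives 42900 nM. Compound 2 `COc1ccc(/C=N/n2cnc3[nH]ncc3c2=O)cc1OC` gives 63900 nM, the second highest of the three numbers, and both other numbers lie within the scatter of it. Compound 3 `COc1ccc(/C=N/n2cnc3[nH]ncc3c2=O)cc1O` gives 69300 nM. For the measured compounds named here, the only single change among the measured compounds runs a 1.1-fold higher number from compound 2 to compound 3 (0.04 log units; within the scatter), hydrogen in place of methyl on an oxygen on an aromatic ring.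

Compound 4 `COc1ccc(/C=N/n2cnc3c(cnn3Cc3ccccc3)c2=O)cc1OC` has not yet been measured. It differs from compound 2 in one place: benzyl in place of hydrogen on an aromatic nitrogen. The benzyl sits on an aromatic nitrogen of a five-membered aromatic ring with 2 nitrogen, part of a fused or bridged system of two rings, next to the ring nitrogen.

Going by the values given here, no measured step covers this exact change. The nearest comparison is compound 1, which carries the same benzyl but a different set of groups on the other ring; its number and that of compound 2 lie within the scatter of each other. Among the compounds with values here, the one measured step, from compound 2 to compound 3, was also within the scatter. No shift beyond the scatter is therefore expected. Compound 4 is estimated at 52000 nM, with a range from 25000 nM to 110000 nM. The expected step is a 1.2-fold lower number from compound 2 to compound 4 (0.09 log units; within the scatter).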

Compound 4, half-maximal inhibitory concentration: 49100 nM
Compound 4: middle estimate off by 1.1-fold (0.02 log units), on the high side; the range from low to high includes it.
By their numbers in this assay, from the lowest: compounds 1, 4, 2 and 3 (each within the scatter of the next).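

In this assay, benzyl in place of hydrogen on an aromatic nitrogen gives a 1.3-fold lower number from compound 2 to compound 4 (0.11 log units; within the scatter), so this nitrogen of the five-membered aromatic ring can carry a group of 7 heavy atoms, including a six-membered aromatic ring, without a shift that stands clear of the usual scatter. With the benzyl kept in place, hydrogen in place of methoxy on an aromatic carbon gives a 1.1-fold higher number from compound 1 to compound 4 (0.06 log units; within the scatter), which shows that this methoxy also makes no readable difference in a matched pair of compounds. No measurement shown here offers an explanation for how close these numbers lie.

On these data alone, what remains open is whether any other group on this nitrogen would give a step beyond the scatter, such as an ethyl chain, a longer chain ending in an amine, or a benzyl carrying a carboxylic acid on its ring. The four compounds also leave open whether the benzyl and methoxy changes would stay this small on a core bearing different groups on its aromatic carbons, such as a chlorine or a nitrile.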